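The source may report more compounds than this note shows. Statements on the series, on what has been measured and on what is new or still open speak of the compounds shown alone.

Compound 1 `CCOc1ccc(C(O)C2OC(=O)c3c(OC)cc(OC)cc32)cc1` is the starting point of this set. In a functional assay on RAW264.7 cells (Mus musculus) for inhibition, read by Griess assay, with stated times of 1 h and 24 h (on this read-out higher numbers stand for weaker inhibition and lower numbers for stronger inhibition), compound 1 gives > 10000 nM, which is a limit of the assay rather than a number. Compound 2 `COc1cc(OC)c2c(c1)C(C(O)c1ccc(OCc3ccccc3)cc1)OC2=O` differs from compound 1 by phenyl in place of methyl on a saturated chain carbon bound to an oxygen on an aromatic ring. In this assay compound 2 gives > 10000 nM, also a limit. Compound 3 `COc1cc(OC)c2c(c1)C(C(O)c1ccc(OCc3ccc(F)cc3)cc1)OC2=O` differs from compound 2 by fluoro in place of hydrogen on an aromatic carbon, and in this assay compound 3 gives 760 nM. The step that the two limits leave unreadable from compound 1 to compound 2 cannot be read because both values sit at the limit of > 10000 nM in this assay, at which 2 of the 3 values shown sit. The steps of an at least 13-fold lower number from compound 1 to compound 3 (1.11 log units; beyond the scatter) and an at least 13-fold lower number from compound 2 to compound 3 (1.11 log units; beyond the scatter) are both readable and large.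

Compound 4 `COc1cc(OC)c2c(c1)C(C(O)c1ccc(OCc3ccc(OC(F)F)cc3)cc1)OC2=O` differs from compound 1 in one place: 4-(difluoromethoxy)phenyl in place of methyl on a saturated chain carbon bound to an oxygen on an aromatic ring. Within the data shown here, the steps that bear on this change are an at least 13-fold lower number from compound 1 to compound 3 (1.11 log units; beyond the scatter), which also replaces methyl with a substituted phenyl at the same place, and an at least 13-fold lower number from compound 2 to compound 3 (1.11 log units; beyond the scatter), which shows that the substituent on that phenyl decides the outcome. The difluoromethoxy group is a different substituent from fluoro, so a step of comparable direction but uncertain size is expected. Compound 4 is expected to show a step of an at least 8.3-fold lower number from compound 1 to compound 4 (0.92 log units; beyond the scatter) from compound 1. The estimate for compound 4 in this assay is 1200 nM, with a range from 300 nM to 6000 nM.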

Compound 4, half-maximal inhibitory concentration: 5030 nM
For compound 4 the middle estimate is 4.2-fold (0.62 log units) below the measured one; measured number inside the range.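

In this assay, the step of a 6.6-fold higher number from compound 3 to compound 4 (0.82 log units; beyond the scatter) shows that the aromatic carbon bearing fluoro in compound 3 can carry a different substituent and still give a measurable number, but that the two substituents are not equivalent. Until now the only contrast at this aromatic carbon was fluoro against hydrogen, and compound 4 adds a third case that lies on the weaker side of compound 3. The comparison with the compounds lacking a number is less firm, with an at least 1.9-fold lower number from compound 1 to compound 4 (0.29 log units; that floor lies within the scatter) and an at least 1.9-fold lower number from compound 2 to compound 4 (0.29 log units; that floor lies within the scatter), and neither step can be sized further because both start from a limit: the limit of > 10000 nM in this assay, at which 2 of the 4 values shown sit.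

The compounds shown carry only hydrogen, fluoro and difluoromethoxy on that aromatic carbon, so it remains open whether chloro, methoxy or trifluoromethyl there would fall nearer to compound 3 or to compound 4. Also open, going by these compounds, is whether an amine or a carboxylic acid on that carbon would keep any measurable inhibition, and no cause for the gap between compound 3 and compound 4 can be read from these data.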